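Trimming the Side Chain of a Small Inhibitor Core

This account rests on a few compounds, and the source may have more. Where it says the series, first, only, none or still open, it means among the compounds named here.

Three compounds sharing one core have been examined in an assay on isolated protein for inhibition of CCR4-NOT transcription complex subunit 7 (Homo sapiens), read by fluorescence; a lower number here means a stronger inhibitor, a higher number a weaker inhibitor. Compound 1 `O=c1[nH]c2ncn(Cc3ccncc3)c2c(=O)n1O` carries a pyridin-4-ylmethyl group on the aromatic nitrogen of the core and gives 23300 nM. Compound 3 `O=c1[nH]c2ncn(CCOc3ccccc3)c2c(=O)n1O`, which bears a phenoxyethyl chain at the same nitrogen instead, gives 10600 nM. Of the two numbers that have been obtained, compound 1 therefore stands highest, and its gap to compound 3 lies beyond the usual scatter of this kind of measurement. Compound 2 `C=CCOn1c(=O)[nH]c2ncn(Cc3ccccc3)c2c1=O`, in which the hydroxyl oxygen of the core is capped with an allyl group, reaches only a limit in this assay, > 1000000 nM; that the limit of > 1000000 nM in this assay, at which 1 of the 3 values shown sits, is one value, not a number.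

Compound 4 `Cn1cnc2[nH]c(=O)n(O)c(=O)c21` has not yet been measured. Relative to compound 1 it differs in one place: hydrogen in place of pyridin-4-yl on a saturated chain carbon bound to an aromatic nitrogen. No step between measured compounds matches this change, so the expectation rests on how the two numbers shown vary with the group on that nitrogen. Because compound 3 sits at 10600 nM and compound 1 at 23300 nM, a larger side chain has so far gone with the lower number, and removing the pyridin-4-yl altogether is expected to move compound 4 the other way. The step from compound 1 to compound 4 is thus expected to be a weakening one, a 2.4-fold higher number from compound 1 to compound 4 (0.37 log units; beyond the scatter), somewhat beyond the scatter. Compound 4 is estimated at 55000 nM, with a likely range from 15000 nM to 200000 nM.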

Compound 4, half-maximal inhibitory concentration: 251000 nM
Beside the measured number, compound 4's estimate is 4.6-fold (0.66 log units) below it, and the stated range ends below it.
By their numbers in this assay, from the lowest: compound 3; then compound 1; then compound 4. At a limit, above all of these: compound 2.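

In this assay, among the compounds shown here, hydrogen in place of pyridin-4-yl on a saturated chain carbon bound to an aromatic nitrogen brings an 11-fold higher number from compound 1 to compound 4 (1.03 log units; beyond the scatter), a large step and the first reading of a change in one place, which no earlier pair of compounds could offer. It shows that this position is not indifferent to what it carries: the number is clearly lower with the pyridin-4-yl present, yet compound 4, stripped of that ring, still gives a measured value of 251000 nM rather than a limit, so the shared core keeps some inhibition on its own. Nothing measured here speaks to why the ring matters at this position.

It remains open whether the ring as such or its nitrogen accounts for the step, since a plain phenyl or a pyridin-2-yl on the same chain carbon, with the hydroxyl of the core left free, is not among the compounds shown. Also open, going by these compounds, is what a simple ethyl or propyl chain, an amine or a carboxylic acid would give at this place, and so how much of the step needs a ring at all.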